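Ester variation on a nitro-thiochromenone core: cytotoxicity notes

The source may report more compounds than this note shows. Statements on the series, on what has been measured and on what is new or still open speak of the compounds shown alone.

The series rests on the shared core of compound 1 `O=C(OC1CCC(CN2CCN(c3cc(=O)c4cc(C(F)(F)F)cc([N+](=O)[O-])c4s3)CC2)CC1)c1ccncc1`, which also appears in compound 2 `O=c1cc(N2CCN(CC3CCC(OS(=O)(=O)c4ccc5ccccc5c4)CC3)CC2)sc2c([N+](=O)[O-])cc(C(F)(F)F)cc12`. In an ADME assay on Vero cells (Chlorocebus sabaeus) for cytotoxicity, read by MTT assay, with a stated time of 48 h (a lower number here means a stronger inhibitor, a higher number a weaker inhibitor), compound 1 gives > 64 ug/mL, a limit of the assay rather than a number. Compound 2 gives > 64 ug/mL in this assay, again a limit. Compound 1 therefore stands at the limit, and there is no measured value within the series to rank it against; both values shown sit there, as the limit of > 64 ug/mL in this assay, at which 2 of the 2 values shown sit, records. For the measured compounds named here, no step between measured compounds can be drawn from the two limits.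

Compound 3 `O=C(OC1CCC(CN2CCN(c3cc(=O)c4cc(C(F)(F)F)cc([N+](=O)[O-])c4s3)CC2)CC1)C1CCCCC1` differs from compound 1 by cyclohexyl in place of pyridin-4-yl on a carbonyl carbon. Going by the values given here, with nothing measured on either side of this change, no step of a particular size can be assigned; the expectation is for no step beyond the scatter, since both values shown sit at the limit of > 64 ug/mL in this assay, at which 2 of the 2 values shown sit, and compound 1 gives only a limit in this assay. Compound 3 is therefore expected to give about 80 ug/mL in this assay, within 40 ug/mL to 160 ug/mL. The estimated step that the limit leaves unreadable from compound 1 to compound 3 is expected to be small, and the assay is expected most likely to report a limit again.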

Compound 3, half-maximal inhibitory concentration: > 64 ug/mL
Compound 3 was reported as a limit; the forecaster's own chance of this, stated with the estimate: 70%; the middle value lies beyond the limit too.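

In this assay compound 3 gives > 64 ug/mL, a limit and not a number. No step between compound 1 and compound 3 can be read, because the series sits at one limit: the limit of > 64 ug/mL in this assay, at which 3 of the 3 values shown sit.

The compounds shown leave open how compound 1, compound 2 and compound 3 rank against one another in this assay.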